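The compounds below may be only part of what the source reports. "The series", "measured", "known", "first", "only" and "open" are said of these compounds alone.

Liver enzymes break down many compounds, so a simple early question is how much of a compound survives incubation with them. In an ADME assay on S9 fraction from liver (Rattus norvegicus) for metabolic stability, read by LC-MS, using NADPH, with a stated time of 30 min (on this read-out higher numbers stand for a more stable compound and lower numbers for a less stable compound), compound 1 (`CCCCCCCCc1ccc(OCC(=O)Cn2nnc(-c3ccccc3)n2)cc1`) gives 33% and compound 2 (`CCCCCCCCc1ccc(OCC(=O)Cn2nnnc2-c2ccc(Cl)cc2)cc1`) gives 45% as the amount left. Compound 2 therefore holds the higher of the two numbers, and the gap between them lies beyond the usual scatter of repeated measurements.

The next molecule is compound 3 (`CCCCCCCCc1ccc(OCC(=O)Cn2nnnc2-c2cccs2)cc1`), which has thiophen-2-yl in place of 4-chlorophenyl on an aromatic carbon. Going by the values given here, compounds 1 and 2 do not differ in just one place, so no measured step directly guides this prediction. Among the compounds with values here, a small fall from compound 2 is expected because compound 2 gives 45%, the higher of the only two numbers known, but this is a weak basis. The expected change is a number 7 percentage points lower from compound 2 to compound 3 (within the scatter) and this estimated step stays within the usual scatter. The estimated value for compound 3 is 38% with an expected range from 22% to 54% in this early prediction.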

Compound 3, percent of the compound remaining: 27%
For compound 3 the middle estimate is 11 percentage points above the measured one; the measured number falls inside the stated range.
By their numbers in this assay, from the lowest: compounds 3 and 1 (each within the scatter of the next); then compound 2.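

Going by these compounds alone, this is the first step in the set that changes a single place, since compounds 1 and 2 differ in more than one. In this assay, putting thiophen-2-yl in place of 4-chlorophenyl, on an aromatic carbon of the five-membered aromatic ring with 4 nitrogen, gives a number 18 percentage points lower from compound 2 to compound 3 (beyond the scatter), so the amount of compound left after incubation does depend on which group sits at this position. Nothing shown here explains why the amount left shifts with this swap.

The swap changes several things at once, replacing a six-membered ring of carbon only with a five-membered ring that holds sulfur and removing the chlorine, and a single step cannot separate these changes from one another. On these data alone, how the amount left would respond to other groups at this same position, such as a pyridin-3-yl ring, a 4-methoxyphenyl group or a simple amine, remains open, as does whether the same swap would give a similar step on a different core.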